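The compounds below may be only part of what the source reports. "The series", "measured", "known", "first", "only" and "open" are said of these compounds alone.

The measured compounds and their values in a functional assay (aorta) with Rattus norvegicus as the target (a higher number here means a weaker inhibitor, a lower number a stronger inhibitor), are these.

Compound 1 `N#CN/C(=N\C1CCCC1)Nc1cc(C(F)(F)F)cc(C(F)(F)F)c1` gives > 300000 nM, which is a limit of the assay and not a number.
Compound 2 `CC(C)CC/N=C(\NC#N)Nc1cc(F)cc(F)c1` gives 85000 nM.
Compound 3 `COc1cc(N/C(=N/C2CCCC2)NC#N)cc(C(F)(F)F)c1` gives 75000 nM.

Compound 1 therefore stands at the edge of what this assay can report, and only a limit is known for it (the limit of > 300000 nM in this assay, at which 1 of the 3 values shown sits). Among the compounds with values here, the one measured step between compounds that differ in a single place, an at least 4.0-fold lower number from compound 1 to compound 3 (0.60 log units; beyond the scatter), concerns methoxy in place of trifluoromethyl on an aromatic carbon; it leaves the double-bonded nitrogen untouched.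

Compound 4 `CCC/N=C(\NC#N)Nc1cc(C(F)(F)F)cc(C(F)(F)F)c1` differs from compound 1 in that change alone: propyl in place of cyclopentyl on a double-bonded nitrogen. Within the data shown here, no measured step bears on a change at this position. Compound 2, which also carries an open chain on its double-bonded nitrogen, gives 85000 nM in this assay, and that value sits among the weakest of the set. Among the measured compounds shown here, with no step at the double-bonded nitrogen to draw on, and with compound 1 known only as a limit, no move beyond the usual scatter is expected from compound 1 to compound 4, and compound 4 is expected to remain a weak inhibitor.

Compound 4 is estimated at 300000 nM, within 100000 nM to 1000000 nM.

The step this estimate means, a number no higher from compound 1 to compound 4 (the limit leaves the size open), is expected to lie within the scatter, with a real chance that this assay again reports only a limit.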

Compound 4, half-maximal inhibitory concentration: 12400 nM
Estimate against measurement, compound 4: 24-fold (1.38 log units) above; the whole stated range lies above it.
By their numbers in this assay, from the lowest: compound 4; then compounds 3 and 2 (each within the scatter of the next). At a limit, above all of these: compound 1.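

Within the data shown here, the change of cyclopentyl to propyl on a double-bonded nitrogen gives an at least 24-fold lower number from compound 1 to compound 4 (1.38 log units; beyond the scatter) in this assay, so this position, which no earlier step touched, bears strongly on the read-out. Compound 4 keeps both trifluoromethyl groups of compound 1, which shows that this aromatic substitution does not by itself hold a compound at the limit of the assay once propyl replaces cyclopentyl. The step gives only a minimum size, not a measured one, because compound 1 is known only as a limit: the limit of > 300000 nM in this assay, at which 1 of the 4 values shown sits.

At this position on this core, the compounds shown compare only one ring with one open chain, so they cannot separate the effect of chain length from that of removing the ring. On these data alone, it remains open whether an ethyl group, a butyl group or a cyclopropyl ring on the double-bonded nitrogen would read like propyl or like cyclopentyl, and whether methoxy in place of trifluoromethyl on an aromatic carbon would change the number of compound 4 as it does that of compound 1.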